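Cytotoxicity on MT2 cells: removing the chloro from compound 2

This account rests on a few compounds, and the source may have more. Where it says the series, first, only, none or still open, it means among the compounds named here.

Measured so far:
compound 1 `O=c1ccn(CCOc2ccccc2Oc2cccc3cc(Cl)ccc23)c(=O)[nH]1`: > 100000 nM
compound 2 `N#Cc1cc2c(Oc3ccccc3OCCn3ccc(=O)[nH]c3=O)cc(Cl)cc2[nH]1`: 81000 nM

In an ADME assay on MT2 cells (Homo sapiens) for cytotoxicity, read by MTT assay (a higher number here means that more compound is tolerated, a lower number that less compound is tolerated), compound 1 reaches only a limit of the assay, > 100000 nM. In this assay, within the data shown here, compound 2 gives 81000 nM, the one actual number in the set so far, and it sits close to the limit of > 100000 nM in this assay, at which 1 of the 2 values shown sits. Among the measured compounds shown here, no pair of measured compounds differs in a single place, so no measured step is available; the two values together show only that both compounds are tolerated at high concentration.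

Compound 3 `N#Cc1cc2c(Oc3ccccc3OCCn3ccc(=O)[nH]c3=O)cccc2[nH]1` is compound 2 after one change: hydrogen in place of chloro on an aromatic carbon. The change removes a single heavy atom from the core of compound 2 and leaves the rest of the molecule untouched. Given that compound 2 already gives 81000 nM, the step from compound 2 to compound 3 is expected to be small and, if anything, toward more compound being tolerated; the expected step is a 1.2-fold higher number from compound 2 to compound 3 (0.09 log units; within the scatter), which lies within the usual scatter. Compound 3 is therefore estimated to give 100000 nM, in the range 50000 nM to 200000 nM.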

Compound 3, half-maximal cytotoxic concentration: 72000 nM
Estimate against measurement, compound 3: 1.4-fold (0.14 log units) above, within the range that was stated.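

In this assay, among these compounds, the exchange of chloro for hydrogen on the aromatic carbon gives a 1.1-fold lower number from compound 2 to compound 3 (0.05 log units; within the scatter), the first measured step. At this position, para to a fused ring and meta to a large group, the chloro is therefore not required for the high concentration tolerated in this cell line, and the values of compound 2 and compound 3 can be read as the same. Compound 1 differs from both in more than one place and gives only a limit of the assay, not a number, so it adds no second step against which this one could be set: the limit of > 100000 nM in this assay, at which 1 of the 3 values shown sits.

Still open, on these data alone, is whether a group other than chloro or hydrogen at this position, such as an amine, a methoxy group or a carboxylic acid, would shift the number beyond the scatter. Also open, as far as these compounds go, is whether the same exchange would read alike on the core of compound 1, and whether changes elsewhere on the shared core, such as a longer chain, would matter more than this one.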